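Sulfonyl groups on the aminomethyl arm of compound 1

The source may hold more compounds than are shown below. What is called first, only, known or untested is meant among the compounds shown, and "the series" means these compounds.

Measured compounds in a functional assay (aorta) for antagonist activity, with Oryctolagus cuniculus as the target; a lower number here means a stronger inhibitor, a higher number a weaker inhibitor:
compound 1 `CCCCc1ccc(CN)c(=O)n1Cc1ccc(-c2ccccc2-c2nn[nH]n2)cc1` gives 20 nM
compound 2 `CCCCc1ccc(CNS(=O)(=O)c2ccc(C)cc2)c(=O)n1Cc1ccc(-c2ccccc2-c2nn[nH]n2)cc1` gives 9 nM
compound 3 `CCCCc1ccc(CN(C)S(=O)(=O)c2ccccc2)c(=O)n1Cc1ccc(-c2ccccc2-c2nn[nH]n2)cc1` gives 2 nM

Compound 1 stands highest of the three numbers in this assay, so it is the weakest inhibitor shown. Compound 4 `CCCCc1ccc(CN(CC)S(C)(=O)=O)c(=O)n1Cc1ccc(-c2ccccc2-c2nn[nH]n2)cc1` differs from it by ethyl(methylsulfonyl)amino in place of amino on a saturated chain carbon bound to an aromatic carbon. Among the compounds with values here, two measured steps bear on this change: a 2.2-fold lower number from compound 1 to compound 2 (0.35 log units; beyond the scatter) and a 10-fold lower number from compound 1 to compound 3 (1.00 log units; beyond the scatter), both lowering the number. Compound 4 carries an alkyl on the nitrogen as compound 3 does, but a smaller sulfonyl than either compound 2 or compound 3, so a step of similar direction, perhaps between those two, is expected. Compound 4 is therefore estimated at 5 nM, within 1.5 nM to 15 nM. This estimate means an expected step of a 4.0-fold lower number from compound 1 to compound 4 (0.60 log units; beyond the scatter).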

Compound 4, half-maximal inhibitory concentration: 2 nM
Estimate against measurement, compound 4: 2.5-fold (0.40 log units) above; the range from low to high includes it.
By their numbers in this assay, from the lowest: compounds 3 and 4 (each within the scatter of the next); then compound 2; then compound 1.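

A small methylsulfonyl serves this position as well as an aromatic sulfonyl does, provided the nitrogen carries an alkyl group: in this assay, the change to ethyl(methylsulfonyl)amino gives a clear gain over the free amine (a 10-fold lower number from compound 1 to compound 4 (1.00 log units; beyond the scatter)) and no separation from the phenylsulfonyl analogue (no change at the digits printed from compound 3 to compound 4 (within the scatter)). It also improves on the nitrogen-hydrogen tosyl-type compound (a 4.5-fold lower number from compound 2 to compound 4 (0.65 log units; beyond the scatter)), although that step changes both the sulfonyl and the nitrogen substituent. No evidence here explains these steps. Open, as far as these compounds go, is whether methylsulfonylamino without the ethyl would match compound 4, and whether an acetyl group could replace the sulfonyl.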